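A 3-cyanophenyl swap at the assay limit

This account rests on a few compounds, and the source may have more. Where it says the series, first, only, none or still open, it means among the compounds named here.

Of the compounds shown here, three sharing one core have so far been measured in an ADME assay on MDBK cells (Bos taurus) for cytotoxicity (on this read-out higher numbers stand for lower toxicity in this test and lower numbers for higher toxicity in this test), and each gives only a limit rather than a number. Compound 1 (`c1ccc(Cn2ccc3nc(-c4ccccc4)nc-3c2)cc1`) gives the limit > 100000 nM in this test. Compound 2 (`Fc1ccccc1Cn1ccc2nc(-c3ccccc3)nc-2c1`) gives the limit > 100000 nM in the same test. As far as these compounds go, compound 3 (`Clc1ccc(Cn2ccc3nc(-c4ccccc4)nc-3c2)cc1`) gives the limit > 100000 nM as well, so its exact standing is unknown.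

Compound 4 (`N#Cc1cccc(Cn2ccc3nc(-c4ccccc4)nc-3c2)c1`) has not yet been measured. It differs from compound 3 by a single change: 3-cyanophenyl in place of 4-chlorophenyl on a saturated chain carbon bound to an aromatic nitrogen.

Among the measured compounds shown here, three measured steps bear on this change. They are a step that the two limits leave unreadable from compound 1 to compound 2, a step that the two limits leave unreadable from compound 1 to compound 3 and a step that the two limits leave unreadable from compound 2 to compound 3. None of them has a readable size, so they offer no measured shift to carry over.

In this assay no step beyond the usual scatter is expected for compound 4, in either direction, because of the limit of > 100000 nM in this assay, at which 3 of the 3 values shown sit, which includes compound 3. The step expected is a number no higher from compound 3 to compound 4 (the limit leaves the size open), and the assay may well report only a limit again. Compound 4 is estimated at 100000 nM, with an expected range from 40000 nM to 200000 nM.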

Compound 4, half-maximal cytotoxic concentration: > 100000 nM
Compound 4: only a limit was reported; the forecaster's own chance of this, stated with the estimate: 85%; the middle value lies on the limit itself.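

Compound 4 gives only a limit, as do compound 1, compound 2 and compound 3, so no step among these four can be read in this assay because they all stand at the same limit: the limit of > 100000 nM in this assay, at which 4 of the 4 values shown sit. In this assay the compounds shown leave open how far each one lies beyond that limit, and whether the groups exchanged among them differ at all.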